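Hydroxyl Position on a Triaryl Core and Cytotoxicity

This account rests on a few compounds, and the source may have more. Where it says the series, first, only, none or still open, it means among the compounds named here.

Three compounds share a core built from three hydroxyphenyl groups around a six-membered aromatic ring with one nitrogen. In a functional assay on DU-145 cells (Homo sapiens) for cytotoxicity, read by CCK-8 assay, with a stated time of 4 days (a higher number here means a weaker inhibitor, a lower number a stronger inhibitor), compound 1 `Oc1ccc(-c2cc(-c3cccc(O)c3)nc(-c3cccc(O)c3)c2)cc1` gives 1760 nM. In this assay compound 2 `Oc1ccccc1-c1cc(-c2ccccc2O)nc(-c2ccccc2O)c1` gives 5040 nM, the higher of the two measured numbers. Compound 3 `Oc1cccc(-c2cc(-c3ccccc3O)cc(-c3cccc(O)c3)n2)c1` reaches only the limit of this assay, > 50000 nM, which is a limit and not a number. The change 4-hydroxyphenyl in place of 2-hydroxyphenyl on an aromatic carbon gives an at least 28-fold lower number from compound 3 to compound 1 (1.45 log units; beyond the scatter), a step that starts from the limit of > 50000 nM in this assay, at which 1 of the 3 values shown sits. The difference between the cores of compound 2 and compound 3 is not broken down here.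

Compound 4 `Oc1ccc(-c2cc(-c3ccccc3O)cc(-c3ccccc3O)n2)cc1` remains to be measured. It differs from compound 2 by 4-hydroxyphenyl in place of 2-hydroxyphenyl on an aromatic carbon, the same kind of change as that from compound 3 to compound 1, though the surroundings differ: here the place is next to the ring nitrogen and meta to two 2-hydroxyphenyl groups, whereas there it was opposite the ring nitrogen and meta to two 3-hydroxyphenyl groups. Resting on compound 3 and its step of an at least 28-fold lower number from compound 3 to compound 1 (1.45 log units; beyond the scatter), compound 4 is expected to show a 3.4-fold lower number from compound 2 to compound 4 (0.53 log units; beyond the scatter). The estimate for compound 4 in this assay is 1500 nM, between 400 nM and 6000 nM.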

Compound 4, half-maximal inhibitory concentration: 360 nM
For compound 4 the middle estimate is 4.2-fold (0.62 log units) above the measured one; the whole stated range lies above it.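

In this assay, 4-hydroxyphenyl in place of 2-hydroxyphenyl lowers the number on a second core, with a 14-fold lower number from compound 2 to compound 4 (1.15 log units; beyond the scatter), so the direction of the step seen on the core of compound 3 carries over to the core of compound 2. Whether its size carries over as well is a separate matter, and the two steps compare as follows: the same change on two cores in this assay, an at least 28-fold lower number (1.45 log units; beyond the scatter) from compound 3 to compound 1 and a 14-fold lower number (1.15 log units; beyond the scatter) from compound 2 to compound 4; the limit leaves it open whether they differ. Compound 3 gives > 50000 nM, which is a limit and not a number, and two cores alone do not show that the change would act the same way on any further core in this series.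

The compounds shown leave open what would happen if an amine or a carboxylic acid took the place of the hydroxyl on the phenyl group. They also leave open what a plain phenyl group without a hydroxyl would give in place of 2-hydroxyphenyl.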